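This account rests on a few compounds, and the source may have more. Where it says the series, first, only, none or still open, it means among the compounds named here.

Compound 1 `Cn1c(-c2ccccc2C(F)(F)F)nnc1C12CCC(CNS(C)(=O)=O)(CC1)CC2`: in an assay on CHO-K1 cells for inhibition of 11-beta-hydroxysteroid dehydrogenase type 2 (Mus musculus), read by scintillation proximity assay (on this read-out lower numbers stand for stronger inhibition and higher numbers for weaker inhibition), compound 1 gives > 4000 nM, which is a limit of the assay rather than a number.
Compound 2 `CCCCCC12CCC(c3nnc(-c4ccccc4C(F)(F)F)n3C)(CC1)CC2`: in this assay compound 2 gives > 4000 nM, again a limit of the assay and not a number.

Compound 2 thus stands at a limit, and no number places it within the measured range. The step that the two limits leave unreadable from compound 1 to compound 2 is unreadable. Compound 3 `CCOCC12CCC(c3nnc(-c4ccccc4C(F)(F)F)n3C)(CC1)CC2` differs from compound 2 by ethoxy in place of butyl on a saturated chain carbon bound to a saturated ring carbon. Within the data shown here, the only measured step at this position is the one from compound 1 to compound 2, and the only evidence on it is the limit of > 4000 nM in this assay, at which 2 of the 2 values shown sit. These data therefore give no ground to expect a step beyond the scatter in either direction in this assay. The step that the limit leaves unreadable from compound 2 to compound 3 that the estimate means is expected to be small. The estimate for compound 3 in this assay is 6000 nM, with a range from 1500 nM to 30000 nM.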

Compound 3, half-maximal inhibitory concentration: > 4000 nM
Compound 3: no number, only a limit; the forecaster's own chance of this, stated with the estimate: 75%; the middle value is on the limit's open side.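

Compound 3, like compound 1 and compound 2, gives a limit of the assay and not a number, so the steps among these three compounds cannot be read: the limit of > 4000 nM in this assay, at which 3 of the 3 values shown sit.

The compounds shown leave open whether any group at this place gives a measurable value in this assay.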